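The source may report more compounds than this note shows. Statements on the series, on what has been measured and on what is new or still open speak of the compounds shown alone.

Compound 1 `Cc1cc(=O)c2c(O)c(CN(C)CC(=O)O)c(O)c([C@H]3CCN(C)C[C@H]3O)c2o1`: 20%
Compound 2 `Cc1oc2c([C@H]3CCN(C)C[C@H]3O)c(O)cc(O)c2c(=O)c1C(O)c1ccc(Cl)cc1`: 41%

Both values come from a functional assay on PC-3 cells (Homo sapiens) for inhibition, read by MTT assay, with a stated time of 48 h, tested at 10 uM (a higher number here means more inhibition of growth at the concentration tested, a lower number less inhibition of growth), and compound 2 stands as the higher of the two, with its gap to compound 1 beyond the scatter. Compound 3 `Cc1oc2c([C@H]3CCN(C)C[C@H]3O)c(O)cc(O)c2c(=O)c1C(O)c1cc(F)cc(F)c1` is not yet measured. It differs from compound 2 by 3,5-difluorophenyl in place of 4-chlorophenyl on a saturated chain carbon bound to an aromatic carbon and an oxygen on a saturated carbon on a saturated chain carbon bound to an aromatic carbon and an oxygen on a saturated carbon. For the measured compounds named here, no measured pair tests this change, so no shift beyond the scatter is assumed. The expected a number 5 percentage points lower from compound 2 to compound 3 (within the scatter) is small, slightly downward and within the scatter. The estimated value for compound 3 is 36% with an expected range from 20% to 52%.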

Compound 3, percent growth inhibition at one concentration: 0%
Beside the measured number, compound 3's estimate is 36 percentage points above it, outside the stated range (below it).
By their numbers in this assay, from the lowest: compound 3; then compound 1; then compound 2.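

Notes on the aryl group on the saturated chain carbon bound to an aromatic carbon and an oxygen: in this assay this position is sensitive to the substitution of the phenyl ring, as 3,5-difluorophenyl in place of 4-chlorophenyl gives a number 41 percentage points lower from compound 2 to compound 3 (beyond the scatter). Compound 1 differs from compound 2 in more than one place and could not show this. Nothing available accounts for the size of the step.

The change alters both halogen and ring pattern at once, leaving their separate contributions unresolved. On these data alone, how a plain phenyl or a benzyl group on the same carbon would stand in this assay remains open.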